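Swapping furan-2-yl for 3-methoxyphenyl in a weak series

This account rests on a few compounds, and the source may have more. Where it says the series, first, only, none or still open, it means among the compounds named here.

In a functional assay on MDA-MB-435 cells (Homo sapiens) for cytotoxicity, read by MTT assay, with a stated time of 72 h (on this read-out lower numbers stand for stronger inhibition and higher numbers for weaker inhibition), compound 1 `N[C@H]1CC[C@H](Nc2c(C(=O)NCc3ccc(F)cc3)nc(N3CCCCS3(=O)=O)c3cccnc23)CC1` gives 5000 nM and compound 3 `CN(C)CCCNc1c(C(=O)NCc2ccc(F)cc2)nc(Br)c2cccnc12` gives 7000 nM.

On these data alone, compound 2 `N[C@H]1CC[C@H](Nc2c(C(=O)NCc3ccco3)nc(Br)c3cccnc23)CC1` is reported only as a limit, > 10000 nM, so its exact position is unknown.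

Compound 4 `COc1cccc(CNC(=O)c2nc(Br)c3cccnc3c2N[C@H]2CC[C@H](N)CC2)c1` differs from compound 2 in one place (3-methoxyphenyl in place of furan-2-yl on a saturated chain carbon bound to an amide-type nitrogen), with 3-methoxyphenyl in place of furan-2-yl on a saturated chain carbon bound to an amide-type nitrogen. Among the measured compounds shown here, no measured step isolates this change. The expected direction rests on compound 3, which gives 7000 nM with a benzyl amide instead. An estimated at least 1.4-fold lower number from compound 2 to compound 4 (0.15 log units; that floor lies within the scatter) is expected in this assay, small and towards lower numbers. For compound 4 the expected value is 7000 nM, with an estimated range from 2500 nM to 20000 nM.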

Compound 4, half-maximal inhibitory concentration: 7000 nM
Compound 4: middle estimate and measured number agree at the digits printed; the measured number falls inside the stated range.
By their numbers in this assay, from the lowest: compounds 1, 3 and 4 (each within the scatter of the next). At a limit, above all of these: compound 2.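

Among the compounds shown here, the swap on a saturated chain carbon bound to an amide-type nitrogen gives the first step in which this place changes alone, and in this assay it reads as an at least 1.4-fold lower number from compound 2 to compound 4 (0.15 log units; that floor lies within the scatter). That step is only a floor, as compound 2 is reported at a limit: the limit of > 10000 nM in this assay, at which 1 of the 4 values shown sits. Compound 4, carrying 3-methoxyphenyl, has a measured value of 7000 nM, so this change gives a number that can be compared directly.

On these data alone, the true size of the step stays open. So does what a plain phenyl ring, or a carboxylic acid in place of the methoxy group, would give on the same core.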